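Trifluoromethoxy for trifluoromethyl on the shared core

The compounds below may be only part of what the source reports. "The series", "measured", "known", "first", "only" and "open" are said of these compounds alone.

The series shares the core of compound 1 `Oc1ccc(-c2cc(-c3cccc(F)c3)cc(-c3ccc(O)cc3)n2)cc1`. In a functional assay on HeLa cells (Homo sapiens) for inhibition (on this read-out lower numbers stand for stronger inhibition and higher numbers for weaker inhibition), compound 1 gives only a limit, > 50000 nM. Compound 2 `Oc1ccc(-c2cc(-c3ccc(C(F)(F)F)cc3)cc(-c3ccccc3O)n2)cc1` likewise gives only a limit in this assay, > 50000 nM. Compound 3 `Oc1ccc(-c2cc(-c3ccc(C(F)(F)F)cc3)cc(-c3ccc(O)cc3)n2)cc1` stands at a limit too, > 50000 nM in this assay. Among the measured compounds shown here, every value shown sits at the limit of > 50000 nM in this assay, at which 3 of the 3 values shown sit, so no compound can be set above another. The two measured steps that lead to compound 3 are unreadable for this reason: a step that the two limits leave unreadable from compound 1 to compound 3 and a step that the two limits leave unreadable from compound 2 to compound 3.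

Compound 4 `Oc1ccc(-c2cc(-c3ccc(OC(F)(F)F)cc3)cc(-c3ccc(O)cc3)n2)cc1` differs from compound 3 by trifluoromethoxy in place of trifluoromethyl on an aromatic carbon. For the measured compounds named here, no measured step bears on this change, and the two steps that do exist leave no size to read; the only pattern across compounds 1, 2 and 3 is that this assay reports a limit in every case. The expectation for compound 4 in this assay is therefore a value at or around the same limit, with no step beyond the scatter, which is what a step that the limit leaves unreadable from compound 3 to compound 4 means. Compound 4 is estimated at 60000 nM, within 20000 nM to 200000 nM.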

Compound 4, half-maximal inhibitory concentration: 16900 nM
Compound 4: middle estimate off by 3.6-fold (0.55 log units), on the high side; the whole stated range lies above it.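

Trifluoromethoxy in place of trifluoromethyl on this aromatic carbon gives an at least 2.9-fold lower number from compound 3 to compound 4 (0.47 log units; beyond the scatter) in this assay, and this is the only step shown whose direction can be read. The earlier steps shown here cannot be read, so the earlier compounds gave no sign that a change on the shared core could move the read-out. Compound 4 is the only compound shown with a measured number rather than a limit: the limit of > 50000 nM in this assay, at which 3 of the 4 values shown sit.

On these data alone, the true size of the step stays open, since compound 3 gives only a limit, and whether 2-hydroxyphenyl in place of 4-hydroxyphenyl would keep the gain alongside trifluoromethoxy is also unknown. As far as these compounds go, it is likewise open whether an amine, a carboxylic acid or a longer chain such as ethoxy on this carbon would give a lower number than compound 4 at 16900 nM.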